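The source may report more compounds than this note shows. Statements on the series, on what has been measured and on what is new or still open speak of the compounds shown alone.

Of the compounds shown here, three sharing one core have been measured in an assay on CHO cells for displacement of a labelled ligand from 5-hydroxytryptamine receptor 1D (Homo sapiens); on this read-out higher numbers stand for weaker inhibition and lower numbers for stronger inhibition. Compound 1 `C[C@@H](NCC1CCN(CCCc2c[nH]c3ccc(-n4cnnc4)cc23)CC1)c1ccccc1` gives 1.4 nM. Compound 2 `CN(Cc1cccs1)C1CCN(CCCc2c[nH]c3ccc(-n4cnnc4)cc23)CC1` gives 4.3 nM. Compound 3 `CN(C1CCN(CCCc2c[nH]c3ccc(-n4cnnc4)cc23)CC1)S(=O)(=O)c1ccccc1` gives 1.5 nM, which places it second highest of the three numbers, sitting within the scatter of compound 1 and clearly apart from compound 2.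

Compound 4 `CN(Cc1ccc(S(C)(=O)=O)cc1)C1CCN(CCCc2c[nH]c3ccc(-n4cnnc4)cc23)CC1` is compound 3 with one change: 4-(methylsulfonyl)benzyl in place of phenylsulfonyl on an amine nitrogen. The most telling measured step is the reverse of that kind of change, where a phenylsulfonyl took the place of an arylmethyl on the same nitrogen and gave a 2.9-fold lower number from compound 2 to compound 3 (0.46 log units; beyond the scatter). The step of a 3.1-fold higher number from compound 1 to compound 2 (0.49 log units; beyond the scatter) also shows that an arylmethyl on this nitrogen sits at the weaker end of the set. Putting an arylmethyl back, now carrying a methylsulfonyl, is therefore expected to move the number modestly upward, by roughly the size of the step between compound 2 and compound 3, as a 2.3-fold higher number from compound 3 to compound 4 (0.37 log units; beyond the scatter). Compound 4 is estimated to give 3.5 nM in this assay, within a range of 1.2 nM to 10 nM.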

Compound 4, half-maximal inhibitory concentration: 18 nM
Estimate against measurement, compound 4: 5.1-fold (0.71 log units) below; measured number above the stated range.
By their numbers in this assay, from the lowest: compounds 1 and 3 (each within the scatter of the next); then compound 2; then compound 4.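

The change from phenylsulfonyl to 4-(methylsulfonyl)benzyl on the amine nitrogen gives, in this assay, a 12-fold higher number from compound 3 to compound 4 (1.08 log units; beyond the scatter), the largest step among these compounds. The earlier arylmethyl example did not show that the ring on this chain carbon matters so much: 4-(methylsulfonyl)phenyl in place of thiophen-2-yl gives a 4.2-fold higher number from compound 2 to compound 4 (0.62 log units; beyond the scatter), so the weaker end of the set depends on the aromatic group and not only on the presence of a saturated chain carbon at this nitrogen. The leaving and entering groups each hold one six-membered aromatic ring and the same count of hydrogen-bond acceptors, so those counts do not separate their results.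

On these data alone, it remains open whether the methylsulfonyl group itself or the benzyl framework accounts for the higher number, a question that a plain benzyl group on the same nitrogen could help to settle. The data shown offer no measured explanation for either step.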